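This account rests on a few compounds, and the source may have more. Where it says the series, first, only, none or still open, it means among the compounds named here.

In a functional assay on U-937 cells (Homo sapiens) for antiproliferative activity, read by MTT assay, with a stated time of 24 h (a higher number here means a weaker inhibitor, a lower number a stronger inhibitor), three compounds sharing one core have been measured. Compound 1 (`CCCCc1oc2ccccc2c1C(=O)c1ccc(OCC(=O)NC(C)C)cc1`) gives 17500 nM, compound 2 (`CCCCc1oc2ccccc2c1C(=O)c1ccc(OCC(=O)N2CCCC2)cc1`) gives 32500 nM and compound 3 (`CCCCc1oc2ccccc2c1C(=O)c1ccc(OCC(=O)N2CCCCC2)cc1`) gives 37100 nM. Compound 2 is thus not separated from either of the others by more than the scatter. Only the outer pair differs beyond it, and modestly, with a 2.1-fold higher number from compound 1 to compound 3 (0.33 log units; beyond the scatter).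

Compound 4 (`CCCCc1oc2ccccc2c1C(=O)c1ccc(OCC(=O)N2CCOCC2)cc1`) has morpholin-4-yl in place of pyrrolidin-1-yl on a carbonyl carbon. Going by the values given here, no measured compound carries morpholin-4-yl, so this exact change has no direct precedent. The closest guide is the swap to piperidin-1-yl, another six-membered non-aromatic ring, which gave a 1.1-fold higher number from compound 2 to compound 3 (0.06 log units; within the scatter). The replacement of isopropylamino by pyrrolidin-1-yl, a 1.9-fold higher number from compound 1 to compound 2 (0.27 log units; within the scatter), was also small. On these steps, no change beyond the scatter is expected in this assay, with any drift toward a slightly higher number. The expected step is a 1.1-fold higher number from compound 2 to compound 4 (0.04 log units; within the scatter). For compound 4 the estimated value is 36000 nM, with an expected range from 18000 nM to 70000 nM.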

Compound 4, half-maximal inhibitory concentration: 45400 nM
Compound 4: the middle estimate sits 1.3-fold (0.10 log units) below what was measured; the measured number falls inside the stated range.
By their numbers in this assay, from the lowest: compounds 1, 2, 3 and 4 (each within the scatter of the next, the first and the last beyond it).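

In this assay, morpholin-4-yl brings a ring oxygen and a hydrogen-bond acceptor that pyrrolidin-1-yl lacks, yet the result is a 1.4-fold higher number from compound 2 to compound 4 (0.15 log units; within the scatter), and the change from piperidin-1-yl gives a 1.2-fold higher number from compound 3 to compound 4 (0.09 log units; within the scatter), so compounds 2, 3 and 4 cannot be told apart at this carbonyl carbon. Compound 1, with isopropylamino, now stands beyond the scatter from a second ring compound, with a 2.6-fold higher number from compound 1 to compound 4 (0.41 log units; beyond the scatter), although compound 2 goes against any split between isopropylamino and the rings, since its step from compound 1 stays within the scatter. No measured evidence is available to explain these steps.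

From the compounds shown here alone, it remains open whether piperazin-1-yl, or a hydroxyl group forming a carboxylic acid, would leave the number at this carbonyl carbon equally unmoved. The compounds shown also all keep the shared core, so whether these small steps hold on another core is unknown.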